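A few compounds are considered here, and "the series" means these few. Any claim that something is new, unique, unknown or untested is made for them only; others in the source may bear on it.

Compound 2 `COc1ccc(F)cc1CNCCCNc1ccnc2cc(CCC(C)C)ccc12` is one of three compounds built on a shared core that have been measured in a physicochemical assay for solubility, with a stated time of 18 h, at pH 7.4; on this read-out lower numbers stand for lower solubility and higher numbers for higher solubility. In this assay compound 2 gives 4200 nM. Compound 1 `CC(C)Cc1ccc2c(NCCCNCc3ccco3)ccnc2c1` gives 4200 nM in this assay, and compound 3 `COc1cccc(CNCCCNc2ccnc3cc(CCC(C)C)ccc23)c1O` gives 4200 nM. On these figures compound 2 stands level with compound 1 and with compound 3, within the usual scatter of such measurements. Among the measured compounds shown here, the only single-point step among the measured compounds, no change at the digits printed from compound 2 to compound 3 (within the scatter), exchanges 5-fluoro-2-methoxyphenyl for 2-hydroxy-3-methoxyphenyl on a saturated chain carbon bound to an amine nitrogen, a different part of the molecule from the change considered here.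

Compound 4 `COc1ccc(F)cc1CNCCCNc1ccnc2cc(CC(C)C)ccc12` differs from compound 2 in one place: isopropyl in place of isobutyl on a saturated chain carbon bound to an aromatic carbon. Cut one bond further out, the same difference reads isopentyl to isobutyl. For the measured compounds named here, no measured step touches this position, so any expectation rests on the broader picture: three compounds, differing elsewhere, all sitting at the same value in this assay. The expected step is a 1.1-fold higher number from compound 2 to compound 4 (0.03 log units; within the scatter), nothing beyond the scatter. Compound 4 is therefore estimated at 4500 nM in this assay, with a range from 2000 nM to 9500 nM.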

Compound 4, solubility: 4200 nM
Beside the measured number, compound 4's estimate is 1.1-fold (0.03 log units) above it, and the stated range covers the measured number.
By their numbers in this assay, from the lowest: compounds 1, 2, 3 and 4 (each within the scatter of the next).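

Among the compounds shown here, exchanging isobutyl for isopropyl on a saturated chain carbon bound to an aromatic carbon gives, in this assay, no change at the digits printed from compound 2 to compound 4 (within the scatter), which is the first direct reading at this position and shows that this change leaves the number where it was. Compound 4 also ties this series to the furan compound: 5-fluoro-2-methoxyphenyl in place of furan-2-yl on a saturated chain carbon bound to an amine nitrogen gives no change at the digits printed from compound 1 to compound 4 (within the scatter), so a second single-point change at the amine end joins the one already seen there, again within the scatter. No measurement at hand offers any explanation for this flat picture.

All four compounds now print the same figure, with compound 4 at 4200 nM, so the compounds shown leave open whether any change at either position can move this read-out at all. For the compounds shown here, a group of another kind on this chain carbon, such as a carboxylic acid, an amine or a much longer chain, is the open case, since isobutyl and isopropyl are the only groups seen here.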